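Amino acid variation at the amide terminus

This account rests on a few compounds, and the source may have more. Where it says the series, first, only, none or still open, it means among the compounds named here.

The series keeps one core and varies the amino acid carried on the amide. Compound 1 `O=C(CN(c1nc(Cl)nc2[nH]cnc12)C1CC1)N[C@@H](CO)C(=O)OCc1ccccc1` in a functional assay on the whole organism (Tail, strain ICR) with Mus musculus as the target, in the tail flick test, with a stated time of 30 min, at a dose of 25 umol/kg by the oral route (a higher number here means a stronger effect of the compound at the dose given, a lower number a weaker effect), gives 31.9%. Compound 2 `O=C(CN(c1nc(Cl)nc2[nH]cnc12)C1CC1)N[C@@H](CC(=O)OCc1ccccc1)C(=O)OCc1ccccc1` gives 34.7% in this assay, and compound 3 `O=C(CN(c1nc(Cl)nc2[nH]cnc12)C1CC1)N[C@@H](CO)C(=O)O` gives 38.7% in this assay. Compound 3 thus stands at the largest of the three numbers, but the gap to compound 2 is within the scatter, as is the step of a number 6.8 percentage points higher from compound 1 to compound 3 (within the scatter). The other measured step, a number 2.8 percentage points higher from compound 1 to compound 2 (within the scatter), is likewise within the scatter. Among the compounds with values here, nothing so far has moved this assay beyond the noise.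

Compound 4 `CC(C)[C@H](NC(=O)CN(c1nc(Cl)nc2[nH]cnc12)C1CC1)C(=O)O` differs from compound 3 by isopropyl in place of hydroxymethyl on a saturated chain carbon bound to an amide-type nitrogen and a carbonyl carbon. Within the data shown here, no measured step changes the group on the saturated chain carbon bound to the amide-type nitrogen and the carbonyl carbon in this way, so only the general picture bears on it: two changes at the amino acid, one at the acid oxygen and one on the side chain, each left this assay within the scatter. The step of a number 2.7 percentage points lower from compound 3 to compound 4 (within the scatter) is therefore expected to be none beyond the scatter. Compound 4 is estimated to give 36% in this assay, with a range from 24% to 48%.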

Compound 4, a percentage reported as activity, at one dose (the size of the read-out at that dose, not a potency): 31.2%
The estimate for compound 4 lay 4.8 percentage points above the measured number; the range from low to high includes it.
By their numbers in this assay, from the lowest: compounds 4, 1, 2 and 3 (each within the scatter of the next).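

At the saturated chain carbon bound to an amide-type nitrogen and a carbonyl carbon, with the free acid kept, isopropyl in place of hydroxymethyl gives a number 7.5 percentage points lower from compound 3 to compound 4 (within the scatter) in this assay, so this position tolerates the loss of the hydrogen-bond donor and acceptor counted on hydroxymethyl without a step beyond the scatter in this pair. Within the data shown here, this is the first side-chain change read on the free acid, and it agrees with the side-chain change on the benzyl ester, a number 2.8 percentage points higher from compound 1 to compound 2 (within the scatter); neither of the two side-chain steps goes against the reading that the side chain has not yet moved this read-out beyond the scatter. No supporting measurement bears on what lies behind this step.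

The compounds shown leave open whether a side chain of another kind at this carbon, such as an aminobutyl chain, a benzyl group or a longer alkyl chain, would give a step beyond the scatter. They also leave open whether isopropyl behaves the same way on the benzyl ester as on the free acid, and how any of these results would look at a dose other than the single one reported.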